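The source may report more compounds than this note shows. Statements on the series, on what has been measured and on what is new or still open speak of the compounds shown alone.

Compound 1 `Cc1ccccc1Oc1ccc(N2CCC[C@H]2CC(=O)O)cc1` gives 5600 nM in a functional assay on cells for agonist activity at Free fatty acid receptor 1 (Mus musculus), read by FLIPR and calcium flux, with a stated time of 100 s; on this read-out lower numbers stand for an effect already at smaller amounts and higher numbers for an effect only at larger amounts of compound. Compound 2 `O=C(O)C[C@@H]1CCCN1c1ccc(Oc2ccccc2)cc1` reaches only the limit of this assay, > 16000 nM. Compound 3 `O=C(O)C[C@@H]1CCCN1c1ccc(Oc2ccccc2F)cc1` gives 6900 nM in this assay.

Compound 3 holds the highest of the two numbers in this assay, though its nearest neighbour, compound 1, lies within the scatter of it, as the step of a 1.2-fold higher number from compound 1 to compound 3 (0.09 log units; within the scatter) shows. Compound 4 `CC(C)(C)c1ccccc1Oc1ccc(N2CCC[C@H]2CC(=O)O)cc1` differs from compound 3 by tert-butyl in place of fluoro on an aromatic carbon. Going by the values given here, two measured steps bear on this position. The step of an at least 2.3-fold lower number from compound 2 to compound 3 (0.36 log units; beyond the scatter) and the step of an at least 2.8-fold higher number from compound 1 to compound 2 (0.45 log units; beyond the scatter) both show that a group at this carbon, in place of hydrogen, goes with a lower number, while methyl and fluoro themselves differ only within the scatter. The tert-butyl group is another substituent at the same place, so for compound 4 no step beyond the scatter in this assay is expected, in either direction, with a 1.3-fold lower number from compound 3 to compound 4 (0.10 log units; within the scatter) as the expected change. Compound 4 is therefore estimated at 5500 nM, in the range 2200 nM to 14000 nM.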

Compound 4, half-maximal effective concentration: > 17000 nM
Compound 4 gave a limit, no number (the forecaster's own chance of this, stated with the estimate: 15%); middle value at least 3.0-fold (0.49 log units) from the limit.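

The earlier compounds shown here showed a group at this aromatic carbon going with a lower number than hydrogen, with methyl and fluoro within the scatter of each other. Tert-butyl does not follow them, giving an at least 2.4-fold higher number from compound 3 to compound 4 (0.39 log units; beyond the scatter) and an at least 3.0-fold higher number from compound 1 to compound 4 (0.48 log units; beyond the scatter), so the earlier pattern does not extend to every group at this place. Compound 4 stands at a limit of this assay, not at a number: the limit of > 17000 nM in this assay, at which 1 of the 4 values shown sits.

The step between compound 2 and compound 4 cannot be read, because compound 2 also stands at a limit: the limit of > 16000 nM in this assay, at which 1 of the 4 values shown sits. The compounds shown leave open how far an ethyl or isopropyl group at this carbon would stay with methyl and fluoro, and whether a methoxy group or a chlorine atom would do so.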